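Notes on the step from allylamino to diethylamino

This account rests on a few compounds, and the source may have more. Where it says the series, first, only, none or still open, it means among the compounds named here.

Measured in a functional assay on the whole organism for positive allosteric modulation, with Mus musculus as the target; a higher number here means that more compound is needed for the effect, a lower number that less compound is needed:
- compound 1 `CCNC1CCCC1N(C(=O)CC)c1ccc(Cl)c(Cl)c1` gives 0.2 mg/kg
- compound 2 `C=CCNC1CCCC1N(C(=O)CC)c1ccc(Cl)c(Cl)c1` gives 0.2 mg/kg

Compound 2 stands level with compound 1 in this assay. Compound 3 `CCC(=O)N(c1ccc(Cl)c(Cl)c1)C1CCCC1N(CC)CC` brings (diethylamino in place of allylamino on a saturated ring carbon), with diethylamino in place of allylamino on a saturated ring carbon. Among the measured compounds shown here, the only measured step is no change at the digits printed from compound 1 to compound 2 (within the scatter), which stays within the scatter. For the measured compounds named here, no measured compound carries diethylamino, so this step is a limited guide. No step beyond the scatter is expected in this assay, and no direction is firmly indicated. The expected step is a 1.5-fold higher number from compound 2 to compound 3 (0.18 log units; within the scatter). Compound 3 is estimated at 0.3 mg/kg, with an expected range of 0.1 mg/kg to 1 mg/kg.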

Compound 3, dose for half-maximal effect: 0.1 mg/kg
For compound 3 the middle estimate is 3.0-fold (0.48 log units) above the measured one, within the range that was stated.
By their numbers in this assay, from the lowest: compounds 3, 1 and 2 (each within the scatter of the next).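

In this assay, diethylamino in place of allylamino on the saturated ring carbon gives a 2.0-fold lower number from compound 2 to compound 3 (0.30 log units; within the scatter), and ethyl in place of hydrogen on the amine nitrogen gives a 2.0-fold lower number from compound 1 to compound 3 (0.30 log units; within the scatter). This position therefore accepts diethylamino, with 0 hydrogen-bond donors, and stays within the scatter of allylamino, with 1 hydrogen-bond donor. No evidence on the cause of this result is at hand.

Still open, from the compounds shown here alone, is whether a longer chain on the amine nitrogen, such as dipropylamino, stays level with these compounds. The same question applies to a ring amine such as pyrrolidine at this position.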